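This account rests on a few compounds, and the source may have more. Where it says the series, first, only, none or still open, it means among the compounds named here.

Three analogues sharing one core have been examined in a functional assay on cells (Cancer cell lines, Homo sapiens) for cytotoxicity, read by sulforhodamine B assay, with a stated time of 48 h; a lower number here means a stronger inhibitor of growth, a higher number a weaker inhibitor of growth. Compound 1 `O=C1N=C(N2N=C(c3ccccc3)CC2c2ccccc2O)S/C1=C1/C(=O)Nc2ccc(Br)cc21` gives 280 nM. Compound 2 `CN(C)c1ccc(C2CC(c3ccccc3)=NN2C2=NC(=O)/C(=C3\C(=O)Nc4ccccc43)S2)cc1` gives 1220 nM. Compound 3 `CN(C)c1ccc(C2CC(c3ccccc3)=NN2C2=NC(=O)/C(=C3\C(=O)Nc4ccc(Br)cc43)S2)cc1` gives 250 nM. On these numbers compound 3 stands at the low end: its separation from compound 1 is a 1.1-fold lower number from compound 1 to compound 3 (0.05 log units; within the scatter), so the two are indistinguishable, while its separation from compound 2 is a 4.9-fold lower number from compound 2 to compound 3 (0.69 log units; beyond the scatter).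

Compound 4 `CN(C)c1ccc(C2CC(c3ccccc3)=NN2C2=NC(=O)/C(=C3\C(=O)Nc4ccc(Cl)cc43)S2)cc1` differs from compound 3 in one place: chloro in place of bromo on an aromatic carbon. Within the data shown here, of the measured steps, only the one from compound 2 to compound 3 touches this position, and there a bromo entering for hydrogen gave a 4.9-fold lower number from compound 2 to compound 3 (0.69 log units; beyond the scatter). A halogen therefore stays in place in compound 4, and the swap of one halogen for another is expected to move the number far less than that step did; in this assay the step from compound 3 to compound 4 is estimated at a 1.4-fold higher number from compound 3 to compound 4 (0.15 log units; within the scatter), a change not expected to exceed the scatter. Compound 4 is accordingly estimated at 350 nM, with a range from 170 nM to 750 nM.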

Compound 4, concentration for 50% growth inhibition: 240 nM
Compound 4: middle estimate off by 1.5-fold (0.16 log units), on the high side; low and high end bracket the measured number.
By their numbers in this assay, from the lowest: compounds 4, 3 and 1 (each within the scatter of the next); then compound 2.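

In this assay, chloro on this aromatic carbon behaves as bromo did, with a 5.1-fold lower number from compound 2 to compound 4 (0.71 log units; beyond the scatter) standing alongside the earlier step from hydrogen to bromo, so the lower number is not confined to bromo. The direct exchange of the two halogens, a 1.0-fold lower number from compound 3 to compound 4 (0.02 log units; within the scatter), does not separate them, and in this pair the choice between chloro and bromo makes no readable difference. Nothing measured here bears on why this should be so.

The compounds shown leave open whether fluoro, a methoxy group or a nitrile on this carbon would keep the number as low as the two halogens do. They also leave open whether chloro would match bromo alongside the 2-hydroxyphenyl group of compound 1, which appears here only with bromo.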